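The compounds below may be only part of what the source reports. "The series", "measured", "known", "first", "only" and "open" are said of these compounds alone.

Compound 2 `COc1ccc(CN2CCN(CC(=O)Nc3ccc(-c4nc(-c5ccccc5)c(-c5ccccc5)n4C)cc3)CC2)cc1` is one of two measured members of a small series built on a shared core. In a functional assay on MCF7 cells (Homo sapiens) for cytotoxicity, read by MTT assay, with a stated time of 24 h (a lower number here means a stronger inhibitor, a higher number a weaker inhibitor), compound 2 gives 80 ug/mL. Compound 1 `CN(C)/C=C/N1CCN(CC(=O)Nc2ccc(-c3nc(-c4ccccc4)c(-c4ccccc4)n3C)cc2)CC1` gives 80 ug/mL in this assay, so compound 2 stands level with compound 1 at the digits shown, and the step of no change at the digits printed from compound 1 to compound 2 (within the scatter) amounted to no change within the scatter. Compound 3 `Cn1c(-c2ccc(NC(=O)CN3CCN(Cc4ccc(Cl)cc4)CC3)cc2)nc(-c2ccccc2)c1-c1ccccc1` has not yet been measured. It differs from compound 2 in one place: chloro in place of methoxy on an aromatic carbon. Among the measured compounds shown here, no measured step bears directly on this exchange; the only step seen so far swapped one whole substituent on an amine nitrogen in a ring for another and left the read-out unmoved. With nothing in the data pointing either way, compound 3 is expected to stay close to compound 2, the expected step of no change at the digits printed from compound 2 to compound 3 (within the scatter) being none beyond the scatter. The estimate for compound 3 is therefore 80 ug/mL, with a range from 40 ug/mL to 160 ug/mL.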

Compound 3, half-maximal inhibitory concentration: 21 ug/mL
Compound 3: the middle estimate sits 3.8-fold (0.58 log units) above what was measured; the whole stated range lies above it.
By their numbers in this assay, from the lowest: compound 3; then compounds 1 and 2 (each within the scatter of the next).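

In this assay, the substituent on the benzyl ring proves to matter at this position, although the earlier exchange of one whole group on the amine nitrogen gave no change at the digits printed from compound 1 to compound 2 (within the scatter). Chloro in place of methoxy, on an aromatic carbon para to a large group, gives a 3.8-fold lower number from compound 2 to compound 3 (0.58 log units; beyond the scatter), and 4-chlorobenzyl in place of 2-(dimethylamino)ethenyl gives a 3.8-fold lower number from compound 1 to compound 3 (0.58 log units; beyond the scatter), so among these compounds a benzyl group on that nitrogen is not enough to lower the number, since the 4-methoxybenzyl of compound 2 left it level with compound 1. No measurement shown here explains why the chloro compound differs from the methoxy compound. As far as these compounds go, whether fluoro, bromo, methyl or a plain hydrogen on the same carbon would read like chloro or like methoxy stays open. From the compounds shown here alone, it is also open whether a dimethylamino group or a carboxylic acid there would lower the number or raise it.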